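Cytotoxicity notes: three measured compounds and one estimate

A few compounds are considered here, and "the series" means these few. Any claim that something is new, unique, unknown or untested is made for them only; others in the source may bear on it.

Measured so far in a functional assay on HepG2 cells (Homo sapiens) for cytotoxicity, read by MTT assay, with a stated time of 48 h; on this read-out higher numbers stand for weaker inhibition and lower numbers for stronger inhibition:
compound 1 `CC1=NN(C(=O)CCc2ccccc2)C(c2cc(Br)ccc2O)C1` gives 17900 nM
compound 2 `CC(=O)Oc1ccccc1C1CC(C)=NN1C(=O)CN1CCC(C(C)=O)CC1` gives 7800 nM
compound 3 `O=C(CCl)N1N=C(c2cc3ccccc3oc2=O)CC1c1ccccc1` gives 2980 nM

Compound 3 stands at the lowest number of the three in this assay. Its gap to compound 2 is beyond the scatter, and its gap to compound 1 is wider still and also beyond the scatter; on this read-out compound 3 is therefore the strongest of the three measured compounds. Among the measured compounds shown here, no pair among the measured compounds differs in a single place, so no isolated step is known from them.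

Compound 4 `CC1CC(C)CN(CC(=O)N2N=C(c3cc4ccccc4oc3=O)CC2c2ccccc2)C1` shares the core of compound 3 and differs from it in one place: 3,5-dimethylpiperidin-1-yl in place of chloro on a saturated chain carbon bound to a carbonyl carbon. The chloro group leaves and a six-membered non-aromatic ring with one hetero atom and one hydrogen-bond acceptor enters on the saturated chain carbon bound to the carbonyl carbon.

For the measured compounds named here, with no measured step of this kind to lean on, the direction is uncertain. Compound 2, which also carries a six-membered non-aromatic ring on a saturated chain carbon bound to a carbonyl carbon, gives 7800 nM, a higher number than compound 3. The step from compound 3 to compound 4 is therefore expected to go toward a higher number, estimated at a 2.3-fold higher number from compound 3 to compound 4 (0.37 log units; beyond the scatter), beyond the scatter but modest. Compound 4 is expected to give about 7000 nM, within a range of 2500 nM to 20000 nM.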

Compound 4, half-maximal inhibitory concentration: "not active" (no number reported)
For compound 4 the study gives words and no number; no gap can be computed for the estimate.
By their numbers in this assay, from the lowest: compound 3; then compound 2; then compound 1.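

In this assay, among the compounds shown here, compound 4 is reported only as "not active", without a number, so no step from compound 3 to compound 4 can be read. Nothing shown here bears on this result. The compounds shown leave open how far 3,5-dimethylpiperidin-1-yl in place of chloro moves the read-out in numerical terms.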